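The source may hold more compounds than are shown below. What is called first, only, known or untested is meant among the compounds shown, and "the series" means these compounds.

Measured in a functional assay on HeLa cells (Homo sapiens) for antiproliferative activity, read by MTT assay, with a stated time of 48 h; on this read-out lower numbers stand for stronger inhibition and higher numbers for weaker inhibition:
- compound 1 `CCOc1cc(-c2ccc3[nH]ccc3c2)cn2c(-c3cc(OC)c(OC)c(OC)c3)nnc12`: 166 nM
- compound 2 `COc1cc(-c2nnc3c(OC)cc(-c4ccc5[nH]ccc5c4)cn23)cc(OC)c1OC`: 85 nM

Compound 2 cannot be separated from compound 1 on these numbers, since the two values lie within the scatter of each other. The next compound, compound 3 `COc1cc(-c2nnc3c(OC(C)C)cc(-c4ccc5[nH]ccc5c4)cn23)cc(OC)c1OC`, carries isopropyl in place of methyl on an oxygen on an aromatic ring. Within the data shown here, only one measured step bears on this change, and it concerns the group on the same oxygen: a 2.0-fold lower number from compound 1 to compound 2 (0.29 log units; within the scatter). Among the measured compounds shown here, no measured compound carries isopropyl there, so the evidence is thin. A step of similar size towards a higher number is therefore expected in this assay, close to the edge of the scatter. The estimated step is a 2.0-fold higher number from compound 2 to compound 3 (0.30 log units; within the scatter). Compound 3 is expected at 170 nM, with an estimated range of 70 nM to 420 nM.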

Compound 3, half-maximal inhibitory concentration: 261 nM
The estimate for compound 3 lay 1.5-fold (0.19 log units) below the measured number, within the range that was stated.
By their numbers in this assay, from the lowest: compounds 2, 1 and 3 (each within the scatter of the next, the first and the last beyond it).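

Among these compounds, on this oxygen, this assay now gives a step that clears the scatter, as isopropoxy replacing methoxy produces a 3.1-fold higher number from compound 2 to compound 3 (0.49 log units; beyond the scatter) and so separates two groups at this position for the first time. Among the compounds shown here, the other step involving the new compound, a 1.6-fold higher number from compound 1 to compound 3 (0.20 log units; within the scatter), stays within the scatter, as did the only earlier step, so compound 1 cannot be told apart from either of the other two compounds. Nothing available explains why the number changes with this group.

The compounds shown leave open how a hydroxyl, a longer chain such as n-butyl, or a chain ending in an amine would behave on this oxygen. They also leave open whether the step from methoxy to isopropoxy would hold on a different group in place of the trimethoxyphenyl ring.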